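Removing a Methoxy: From Compound 3 to Compound 4

The compounds below may be only part of what the source reports. "The series", "measured", "known", "first", "only" and "open" are said of these compounds alone.

Compound 1 `COc1ccc2c(/C=C/C(=O)c3cc(OC)c(OC)c(SC)c3)c[nH]c2c1` and compound 2 `COc1cc(C(=O)/C=C/c2c[nH]c3ccccc23)cc(SC)c1OC` form a measured pair. In a functional assay on MCF7 cells (Homo sapiens) for antiproliferative activity, read by MTT assay, with a stated time of 48 h (on this read-out lower numbers stand for stronger inhibition and higher numbers for weaker inhibition), compound 1 gives 101 nM. In the same assay, this assay, compound 2 gives 186 nM. The change between the two is hydrogen in place of methoxy on an aromatic carbon and it made the step of a 1.8-fold higher number from compound 1 to compound 2 (0.27 log units; within the scatter). Compound 3 `COc1ccc2c(/C=C(\C)C(=O)c3cc(OC)c(OC)c([Se]C)c3)c[nH]c2c1` carries a different core; how its core differs from that of compound 1 is not broken down here. In this assay compound 3 gives 35 nM, the lowest of the three numbers and beyond the scatter from both compound 1 and compound 2.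

Compound 4 `COc1cc(C(=O)/C(C)=C/c2c[nH]c3ccccc23)cc([Se]C)c1OC` has not yet been measured. It differs from compound 3 by hydrogen in place of methoxy on an aromatic carbon, which is the same change as that from compound 1 to compound 2; among the compounds shown it occurs twice in all. Going by the values given here, the step of a 1.8-fold higher number from compound 1 to compound 2 (0.27 log units; within the scatter) is the only guide to its size. Because of a 1.8-fold higher number from compound 1 to compound 2 (0.27 log units; within the scatter) a step of similar size is expected here. For the move from compound 3 to compound 4 the expected step is a 1.7-fold higher number from compound 3 to compound 4 (0.23 log units; within the scatter). This rests on a single measured pair, so the range is kept wide. For compound 4 in this assay the estimate is 60 nM. The lower end expected for compound 4 is 30 nM. The upper end expected for compound 4 is 130 nM.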

Compound 4, half-maximal inhibitory concentration: 59 nM
For compound 4 the middle estimate is 1.0-fold (0.01 log units) above the measured one, within the range that was stated.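

In this assay, hydrogen in place of methoxy on an aromatic carbon gave a 1.7-fold higher number from compound 3 to compound 4 (0.23 log units; within the scatter), and set beside the earlier step, the change reads alike on the two cores: the same change on two cores in this assay, a 1.8-fold higher number (0.27 log units; within the scatter) from compound 1 to compound 2 and a 1.7-fold higher number (0.23 log units; within the scatter) from compound 3 to compound 4, 1.1-fold (0.04 log units) apart, within the scatter of two such steps. Since each step lies within the scatter, the pairs show that this change did not move the number beyond the scatter on either core, not that removing the methoxy has a real effect of a fixed size that travels with it. Two pairs on two cores also show nothing about how the change would read on a third core, and they give no reason why the two steps agree.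

Among the compounds shown, this aromatic carbon carries only methoxy or hydrogen, so it remains open whether another group there, such as a hydroxyl, a fluorine, an amine or a longer chain like ethoxy, would give a step beyond the scatter. All the numbers shown come from this assay, so whether the agreement between the two steps holds on other cells or at another time point also remains open.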